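The source may hold more compounds than are shown below. What is called first, only, known or untested is meant among the compounds shown, and "the series" means these compounds.

Measured so far in an ADME assay on WI-38 cells (Homo sapiens) for cytotoxicity, read by MTT assay, with a stated time of 72 h; on this read-out lower numbers stand for stronger inhibition and higher numbers for weaker inhibition:
- Compound 1 `O=C(CCc1cccc2c1B(O)OC2)Nc1ccc(F)cc1`: 12000 nM
- Compound 2 `C#Cc1ccc(NC(=O)CCc2cccc3c2B(O)OC3)cc1`: > 100000 nM, a limit of the assay and not a number
- Compound 3 `CC(C)(C)c1ccc(NC(=O)CCc2cccc3c2B(O)OC3)cc1`: 55000 nM

Of the two exact numbers, the higher belongs to compound 3, at 55000 nM. The gap to its nearest neighbour is a 4.6-fold higher number from compound 1 to compound 3 (0.66 log units; beyond the scatter).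

Compound 4 `CCOC(=O)c1ccc(NC(=O)CCc2cccc3c2B(O)OC3)cc1` carries ethoxycarbonyl in place of tert-butyl on an aromatic carbon.

Three measured steps change a group on this aromatic carbon. Two start from the fluoro compound: an at least 8.3-fold higher number from compound 1 to compound 2 (0.92 log units; beyond the scatter) and a 4.6-fold higher number from compound 1 to compound 3 (0.66 log units; beyond the scatter). The third, an at least 1.8-fold lower number from compound 2 to compound 3 (0.25 log units; that floor lies within the scatter), does not start from fluoro and is the closer guide here, so no step beyond the scatter is expected in this assay.

The expected step is a 1.2-fold lower number from compound 3 to compound 4 (0.09 log units; within the scatter).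

For compound 4 the estimate is 45000 nM, with an expected range from 15000 nM to 100000 nM.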

Compound 4, half-maximal inhibitory concentration: > 100000 nM
Compound 4: a limit, no number; the forecaster's own chance of this, stated with the estimate: 20%; middle value at least 2.2-fold (0.34 log units) from the limit.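

In this assay, the result for compound 4 is a limit of the assay and not a number, so the change from tert-butyl to ethoxycarbonyl gives only a floor that does not clear the scatter: an at least 1.8-fold higher number from compound 3 to compound 4 (0.25 log units; that floor lies within the scatter). Against fluoro the change is clear, with an at least 8.3-fold higher number from compound 1 to compound 4 (0.92 log units; beyond the scatter), and ethoxycarbonyl is the first group here with hydrogen-bond acceptors at this position. The step between compound 2 and compound 4 cannot be read, as both stand at a limit: the limit of > 100000 nM in this assay, at which 2 of the 4 values shown sit.

From the compounds shown here alone, whether an amine or a carboxylic acid on this aromatic carbon would give a number as low as that of compound 1 stays open.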